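Swapping acetyl for dimethylamino on a pyrazole-linked aryl

A few compounds are considered here, and "the series" means these few. Any claim that something is new, unique, unknown or untested is made for them only; others in the source may bear on it.

Within the data shown here, compound 1 `COc1cc(C)cc(-c2c(-c3ccnc(-c4ccc(C(C)=O)cc4)c3)cnn2CC#N)c1` sits lowest of the two numbers so far: in a functional assay on SK-MEL-2 cells (Homo sapiens) for cytotoxicity, read by sulforhodamine B assay, with a stated time of 48 h, tested at 0.01 uM (a lower number here means a stronger effect, a higher number a weaker effect of the compound at the concentration tested), compound 1 gives 90%. Compound 2 `COc1cc(C)cc(-c2nn(CC#N)cc2-c2ccnc(-c3ccc(N(C)C)cc3)c2)c1` lies higher, as in this assay compound 2 gives 116%, a gap beyond the usual scatter. Compound 3 `COc1cc(C)cc(-c2c(-c3ccnc(-c4ccc(N(C)C)cc4)c3)cnn2CC#N)c1` is the next step from compound 1: dimethylamino in place of acetyl on an aromatic carbon. Among the measured compounds shown here, with no measured step for this exact change, the expected shift a number 18 percentage points higher from compound 1 to compound 3 (beyond the scatter) is upward, beyond the scatter, guided by the value of compound 2 116%. For compound 3 in this assay the estimate is 108%, within 92% to 124%.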

Compound 3, a percentage reported as activity, at one concentration (the size of the read-out at that concentration, not a potency): 66%
Compound 3: the middle estimate sits 42 percentage points above what was measured, and the stated range ends above it.
By their numbers in this assay, from the lowest: compound 3; then compound 1; then compound 2.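

Among these compounds, the step of a number 24 percentage points lower from compound 1 to compound 3 (beyond the scatter) in this assay is the first change in a single place, and it moves the read-out toward a stronger effect. It shows that the substituent on this aromatic carbon, para to a large group, affects the result, and that acetyl is not required there for the effect seen at this concentration. No available evidence accounts for the shift. The compounds shown leave open how a primary amine or a carboxylic acid would read at this position.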